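A few compounds are considered here, and "the series" means these few. Any claim that something is new, unique, unknown or untested is made for them only; others in the source may bear on it.

Measured so far:

compound 1 `O=C(NCCNS(=O)(=O)c1sccc1-c1ccccc1Oc1ccc(O)c(O)c1)Nc1cc(Cl)cc(Cl)c1` — in an ADME assay on HEK-293T cells (Homo sapiens) for cytotoxicity, read by CCK-8 assay, with a stated time of 48 h (on this read-out lower numbers stand for stronger inhibition and higher numbers for weaker inhibition), compound 1 gives 10700 nM
compound 2 `Cc1ccc(-c2ccsc2S(=O)(=O)NCCNC(=O)Nc2cc(Cl)cc(Cl)c2)c(Oc2ccc(O)c(O)c2)c1` — in this assay compound 2 gives 6700 nM
compound 3 `O=S(=O)(NCCNC(=S)Nc1cc(C(F)(F)F)cc(C(F)(F)F)c1)c1sccc1-c1ccccc1Oc1ccc(O)c(O)c1` — in this assay compound 3 gives 7500 nM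

Compounds 1 and 2 differ in one place only, (methyl in place of hydrogen on an aromatic carbon), and the step in this assay is a 1.6-fold lower number from compound 1 to compound 2 (0.20 log units; within the scatter). The three values sit close to one another: the distance from compound 3 to compound 2 and the distance from compound 3 to compound 1 both stay inside the usual scatter, so no order among them can be read. Compound 3 carries a different core from compound 1; how the two cores differ is not broken down here.

Compound 4 `Cc1ccc(-c2ccsc2S(=O)(=O)NCCNC(=S)Nc2cc(C(F)(F)F)cc(C(F)(F)F)c2)c(Oc2ccc(O)c(O)c2)c1` is not yet measured. It differs from compound 3 by methyl in place of hydrogen on an aromatic carbon. Going by the values given here, this is the same change as the one from compound 1 to compound 2, made at the same place on the ring of the core of compound 3. The expected step from compound 3 to compound 4 in this assay is a 1.5-fold lower number from compound 3 to compound 4 (0.18 log units; within the scatter), set beside the measured step of a 1.6-fold lower number from compound 1 to compound 2 (0.20 log units; within the scatter). The expectation rests on that single earlier occurrence, which itself stays within the scatter, so the estimate is essentially that compound 4 will land near compound 3 with a slight lean toward a lower number. Compound 4 is therefore estimated at 5000 nM, with a range from 2500 nM to 10000 nM.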

Compound 4, half-maximal inhibitory concentration: 8000 nM
Compound 4: middle estimate off by 1.6-fold (0.20 log units), on the low side; the measured number falls inside the stated range.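

In this assay, methyl in place of hydrogen on an aromatic carbon of the core of compound 3 gives a 1.1-fold higher number from compound 3 to compound 4 (0.03 log units; within the scatter), a step that cannot be told from repeated measurement. Set beside the same change on the core of compound 1, the two steps cannot be told apart either: the same change on two cores in this assay, a 1.6-fold lower number (0.20 log units; within the scatter) from compound 1 to compound 2 and a 1.1-fold higher number (0.03 log units; within the scatter) from compound 3 to compound 4, 1.7-fold (0.23 log units) apart, within the scatter of two such steps

So, on these two cores, the change gives no readable step and the cores show no readable difference in how they take it, but this rests on only two pairs, neither with a step beyond the scatter, and it shows neither that the methyl has an effect of its own nor that a larger step would carry from one core to the other.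

The compounds shown hold only hydrogen or methyl at this place, which leaves open whether an amine, a carboxylic acid or a longer chain there would give a readable step in this assay. On these data alone, all four compounds also carry the 3,4-dihydroxyphenoxy group, so how these numbers would stand with a methoxy group or a plain phenoxy group in its place remains open as well.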